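Swapping Pyridinylmethyl for Isopropyl on a Piperazine Nitrogen

The compounds below may be only part of what the source reports. "The series", "measured", "known", "first", "only" and "open" are said of these compounds alone.

Compound 1 `CN(C[C@H]1Cc2c(cccc2N2CCN(Cc3ccccn3)CC2)CN1)[C@H]1CCCc2cccnc21` gives the lowest number of the three measured compounds in a functional assay on CCRF-CEM cells for antagonist activity at C-X-C chemokine receptor type 4 (Homo sapiens), read by calcium flux, with stated times of 25 min and 90 s (a lower number here means a stronger inhibitor, a higher number a weaker inhibitor), at 4.47 nM. Compound 2 `C[C@@H]1CN(c2cccc3c2C[C@H](CN(C)[C@H]2CCCc4cccnc42)NC3)C[C@H](C)N1` gives 61 nM in this assay, and compound 3 `CN(C[C@@H]1Cc2c(cccc2N2CCNCC2)CN1)[C@H]1CCCc2cccnc21` gives 313 nM; both gaps from compound 1 lie beyond the usual scatter, so compound 1 is the strongest inhibitor of the three. Compound 4 `CC(C)N1CCN(c2cccc3c2C[C@H](CN(C)[C@H]2CCCc4cccnc42)NC3)CC1` is not yet measured. It differs from compound 1 in one place: isopropyl in place of (pyridin-2-yl)methyl on an amine nitrogen in a ring. Compound 3, carrying no group on that ring nitrogen, gives a far higher number than compound 1, and isopropyl is a small group. The step of an 11-fold higher number from compound 1 to compound 4 (1.05 log units; beyond the scatter) is therefore expected to be a moderate weakening, beyond the scatter. Compound 4 is estimated at 50 nM, in a range from 10 nM to 250 nM.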

Compound 4, half-maximal inhibitory concentration: 16.9 nM
Estimate against measurement, compound 4: 3.0-fold (0.47 log units) above; low and high end bracket the measured number.
By their numbers in this assay, from the lowest: compound 1; then compound 4; then compound 2; then compound 3.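

In this assay, replacing (pyridin-2-yl)methyl on this ring nitrogen with isopropyl, which has no ring and no hydrogen-bond acceptor, gives a 3.8-fold higher number from compound 1 to compound 4 (0.58 log units; beyond the scatter), so the smaller group costs only a modest part of the activity. Changing the group on the aromatic carbon to 4-isopropylpiperazin-1-yl from 3,5-dimethylpiperazin-1-yl gives a 3.6-fold lower number from compound 2 to compound 4 (0.56 log units; beyond the scatter), a modest gain. Nothing measured here explains either step. Going by these compounds, whether a benzyl group, with a ring carrying no nitrogen, or a longer chain such as n-butyl would match compound 1 remains open.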